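Methylamino in place of methoxy on a shared core

The source may hold more compounds than are shown below. What is called first, only, known or untested is meant among the compounds shown, and "the series" means these compounds.

Two analogues built on one shared core have been examined in a functional assay on MT4 cells (Homo sapiens) for cytotoxicity; on this read-out lower numbers stand for higher toxicity in this test and higher numbers for lower toxicity in this test. Compound 1 `CN(C)c1ncnc2c1ncn2[C@@H]1O[C@H](CO[Si](C)(C)C(C)(C)C)[C@@]2(OS(=O)(=O)C=C2N)[C@H]1O[Si](C)(C)C(C)(C)C` carries a dimethylamino group on its aromatic carbon, and in this assay compound 1 gives 15000 nM. Compound 2 `COc1ncnc2c1ncn2[C@@H]1O[C@H](CO[Si](C)(C)C(C)(C)C)[C@@]2(OS(=O)(=O)C=C2N)[C@H]1O[Si](C)(C)C(C)(C)C` carries a methoxy group in the same place, and in this assay compound 2 gives 21000 nM. For the measured compounds named here, the one step measured so far, a 1.4-fold higher number from compound 1 to compound 2 (0.15 log units; within the scatter), lies within the scatter, so compound 2 shows the higher of the two numbers without standing apart from compound 1.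

Compound 3 `CNc1ncnc2c1ncn2[C@@H]1O[C@H](CO[Si](C)(C)C(C)(C)C)[C@@]2(OS(=O)(=O)C=C2N)[C@H]1O[Si](C)(C)C(C)(C)C` differs from compound 2 in a single place: methylamino in place of methoxy on an aromatic carbon. The methylamino group shares a methyl with the dimethylamino group of compound 1 and a single-atom link to the ring with the methoxy of compound 2. Going by the values given here, because the only step that bears on this exchange, a 1.4-fold higher number from compound 1 to compound 2 (0.15 log units; within the scatter), stayed within the scatter, the change is expected to bring a 1.2-fold lower number from compound 2 to compound 3 (0.07 log units; within the scatter), nothing beyond the scatter. Compound 3 is therefore expected to give about 18000 nM in this assay, within a range from 9000 nM to 40000 nM.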

Compound 3, half-maximal cytotoxic concentration: 14000 nM
Compound 3: the middle estimate sits 1.3-fold (0.11 log units) above what was measured, within the range that was stated.
By their numbers in this assay, from the lowest: compounds 3, 1 and 2 (each within the scatter of the next).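

In this assay, the exchange of methoxy for methylamino on this aromatic carbon, which brings in a hydrogen-bond donor, gives a 1.5-fold lower number from compound 2 to compound 3 (0.18 log units; within the scatter), and hydrogen in place of methyl on the nitrogen gives a 1.1-fold lower number from compound 1 to compound 3 (0.03 log units; within the scatter). The earlier pair covered only methoxy and dimethylamino, whereas all three compounds now give steps within the scatter, so methoxy, methylamino and dimethylamino cannot be told apart at this place in this test, and the hydrogen-bond donor that enters with methylamino brings no step beyond the scatter. Nothing available here explains this result or bears on it.

On these data alone, it remains open whether any group at this aromatic carbon would bring a step beyond the scatter, for example an unsubstituted amine, a longer chain such as butylamino, or a carboxylic acid. It is also open whether the same exchanges would stay within the scatter on a different core, since all three compounds shown here share one core.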